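Urea Nitrogen Substituent Change in a Urotensin Receptor Series

The compounds below may be only part of what the source reports. "The series", "measured", "known", "first", "only" and "open" are said of these compounds alone.

Compound 1 `Cc1ccc(C(=O)NC(CCN(C)C)c2ccc(Cl)cc2)c(C)c1` gives 147% in an assay on NIH3T3 cells with Urotensin-2 receptor (Homo sapiens) as the target; a lower number here means a smaller maximal response, a higher number a larger maximal response. Compound 2 `Cc1ccccc1NC(=O)NC(CCN(C)C)c1ccc(Cl)cc1` carries a (2-methylphenyl)amino in place of the 2,4-dimethylphenyl on the carbonyl carbon, and in this assay compound 2 gives 175%, a change of a number 28 percentage points higher from compound 1 to compound 2 (beyond the scatter). Among the two measured compounds, compound 2 therefore stands highest, with compound 1 as its nearest neighbour and the gap between them beyond the scatter.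

Compound 3 `CN(C)CCC(NC(=O)NCc1ccccc1)c1ccc(Cl)cc1` differs from compound 2 by benzyl in place of 2-methylphenyl on an amide-type nitrogen. For the measured compounds named here, the only measured step, the one from compound 1 to compound 2, altered the group on the other side of the urea, on the carbonyl carbon, and was modest in size. Going by the values given here, no step in the data touches the group on the amide-type nitrogen, so the expectation rests on the modest size of the one known step rather than on a direct precedent. A step of similar or smaller size, in either direction, is the most that seems warranted, and a result within the scatter is plausible. Compound 3 is therefore expected to give 160%, with a range from 120% to 200%. The expected step is a number 15 percentage points lower from compound 2 to compound 3 (beyond the scatter).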

Compound 3, largest response reached (reported as efficacy), in percent of the reference or control that the assay uses: 179%
Compound 3: middle estimate off by 19 percentage points, on the low side; the measured number falls inside the stated range.
By their numbers in this assay, from the lowest: compound 1; then compounds 2 and 3 (each within the scatter of the next).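

Compound 3 shows that, on this amide-type nitrogen, benzyl in place of 2-methylphenyl leaves the two compounds indistinguishable in this assay (a number 4 percentage points higher from compound 2 to compound 3 (within the scatter)), although the replacement has the same heavy-atom count and is joined differently. The earlier compounds had shown only a change on the carbonyl carbon, and the new pair adds that the higher level relative to compound 1 is not confined to the (2-methylphenyl)amino group, since benzylamino in place of 2,4-dimethylphenyl on that carbon also gives a large step (a number 32 percentage points higher from compound 1 to compound 3 (beyond the scatter)). Nothing available explains why these two groups read alike or why both stand above compound 1.

The compounds shown leave open whether a longer chain on the same nitrogen, such as 2-phenylethyl, or a ring of another kind, such as cyclohexyl or pyridyl, would stay within the same range. They also leave open what would follow from replacing the dimethylamino group, which all three compounds share, with another amine such as pyrrolidine.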